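Isoxazole aryl swap in a chromene acid series

The source may report more compounds than this note shows. Statements on the series, on what has been measured and on what is new or still open speak of the compounds shown alone.

Measured so far:
compound 1 `O=C(O)C1=Cc2ccccc2OC1(OCc1cc(-c2ccc([N+](=O)[O-])cc2)no1)C(F)(F)F`: > 150000 nM
compound 2 `O=C(O)C1=Cc2ccccc2OC1(OCc1cc(-c2ccc3ccccc3c2)no1)C(F)(F)F`: > 150000 nM

Compound 2 stands only at a limit of a functional assay on A549 cells (Homo sapiens) for inhibition, read by MTT assay, with a stated time of 24 h; a higher number here means a weaker inhibitor, a lower number a stronger inhibitor; no number is known for it. Compound 1 likewise sits at a limit. The step that the two limits leave unreadable from compound 1 to compound 2 is unreadable because both values sit at the limit of > 150000 nM in this assay, at which 2 of the 2 values shown sit. Compound 3 `O=C(O)C1=Cc2ccccc2OC1(OCc1cc(-c2ccc(F)cc2)no1)C(F)(F)F` differs from compound 2 by 4-fluorophenyl in place of naphthalen-2-yl on an aromatic carbon. Among the compounds with values here, no measured step bears on this change, so no direction beyond the scatter can be read from the series. Compound 3 is expected to give 200000 nM, between 100000 nM and 500000 nM, most probably again as a limit. The expected step that the limit leaves unreadable from compound 2 to compound 3 is therefore near nil.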

Compound 3, half-maximal inhibitory concentration: > 150000 nM
Compound 3: no number, only a limit; the forecaster's own chance of this, stated with the estimate: 85%; the middle value is on the limit's open side.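

No new step can be read between compound 1, compound 2 and compound 3, because all three values are limits: the limit of > 150000 nM in this assay, at which 3 of the 3 values shown sit.

The compounds shown leave open how 4-nitrophenyl, naphthalen-2-yl and 4-fluorophenyl rank, and whether any group at this place gives a number rather than a limit.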